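A few compounds are considered here, and "the series" means these few. Any claim that something is new, unique, unknown or untested is made for them only; others in the source may bear on it.

Compound 1 `Clc1ccc2[nH]c(SCc3ccccc3Oc3ccccc3)nc2c1` was examined in an assay on isolated protein for inhibition of Indoleamine 2,3-dioxygenase 1 (Homo sapiens), with a stated time of 60 min, tested at 10 uM (on this read-out higher numbers stand for more inhibition at the one concentration tested (going by the name of the read-out) and lower numbers for less inhibition), and gave 30%, the higher of the two numbers recorded so far. Going by the values given here, the only other measured compound, compound 2 `Clc1ccc2sc(SCc3ccccc3CCc3ccccc3)nc2c1`, returned 9% in this assay, a reading that sits beyond the scatter from that of compound 1; yet compound 2 differs from compound 1 in more than one place, so no single step can be drawn between them. Compound 3 `Clc1ccc2[nH]c(SCc3ccccc3OCc3ccccc3)nc2c1` differs from compound 1 in one place only: benzyl in place of phenyl on an oxygen on an aromatic ring. No measured pair shares this change, so the size of its effect has no precedent among these compounds. The step of a number 2 percentage points lower from compound 1 to compound 3 (within the scatter) is expected to be small and to lie within the scatter. Compound 3 is therefore estimated at 28%, with a range from 10% to 45%.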

Compound 3, a percentage reported as inhibition, at one concentration (the size of the read-out at that concentration, not a potency): 3%
Compound 3: the middle estimate sits 25 percentage points above what was measured; measured number outside the range, below it.
By their numbers in this assay, from the lowest: compounds 3 and 2 (each within the scatter of the next); then compound 1.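

At this position, benzyl in place of phenyl on the oxygen gives a number 27 percentage points lower from compound 1 to compound 3 (beyond the scatter) in this assay, the only step among these compounds that can be read at a single place. The change from phenoxy to benzyloxy is therefore not neutral here, even though both groups carry one six-membered aromatic ring of carbon only and neither has a hydrogen-bond donor or acceptor. Nothing available accounts for this loss of inhibition.

On these data alone, it remains open whether the loss is particular to benzyl or would follow from other replacements of phenyl on this oxygen, such as a methyl group, a longer chain or a chain ending in an amine. As far as these compounds go, it also remains open how this step would look at concentrations other than the single one tested.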